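Working notes: from compound 2 to compound 3

The source may hold more compounds than are shown below. What is called first, only, known or untested is meant among the compounds shown, and "the series" means these compounds.

In an ADME assay on PANC-1 cells (Homo sapiens) for cytotoxicity, read by MTT assay (on this read-out lower numbers stand for higher toxicity in this test and higher numbers for lower toxicity in this test), the series has so far produced no numerical reading. Compound 1 `Cc1nc(-c2cccnc2)sc1-c1nnc(-c2cccc(Cl)c2Cl)o1` gives > 100 ug/mL, which is a limit of the assay and not a number. Compound 2 `Cc1ccccc1-c1nnc(-c2sc(-c3cccnc3)nc2C)o1` gives > 100 ug/mL, again a limit. Compound 2 therefore stands at the limit of > 100 ug/mL in this assay, at which 2 of the 2 values shown sit.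

The next change leads to compound 3 `Cc1nc(-c2cccnc2)sc1-c1nnc(-c2ccc(O)cc2)o1` and places 4-hydroxyphenyl in place of 2-methylphenyl on an aromatic carbon. The place is on a five-membered aromatic ring with 2 nitrogen and 1 oxygen.

Within the data shown here, the one measured step that bears on this is a step that the two limits leave unreadable from compound 1 to compound 2, which exchanges the group at the same place. Its size cannot be read, so it supplies no magnitude and no direction to carry over. No step beyond the scatter is therefore expected in this assay, and another reading at the limit is likely. The estimated change is a step that the limit leaves unreadable from compound 2 to compound 3. For compound 3 the expected value is 120 ug/mL, with an estimated range from 60 ug/mL to 240 ug/mL.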

Compound 3, half-maximal cytotoxic concentration: > 100 ug/mL
Compound 3: a limit, no number; the forecaster's own chance of this, stated with the estimate: 70%; the middle value does not contradict the limit.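

In this assay compound 3 gives > 100 ug/mL, a limit of the assay and not a number. No step among compound 1, compound 2 and compound 3 can be read, and all three sit together: the limit of > 100 ug/mL in this assay, at which 3 of the 3 values shown sit.

The compounds shown leave open whether 2,3-dichlorophenyl, 2-methylphenyl and 4-hydroxyphenyl differ at all in this assay.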